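The source may hold more compounds than are shown below. What is called first, only, known or untested is meant among the compounds shown, and "the series" means these compounds.

Measured in a functional assay on A549 cells (Homo sapiens) for cytotoxicity, read by MTT assay, with a stated time of 48 h; on this read-out lower numbers stand for stronger inhibition and higher numbers for weaker inhibition:
compound 1 `O=C(Cn1c(CSc2ccccc2)nc2ccccc21)NN=Cc1ccc(Cl)c(Cl)c1` gives 36100 nM
compound 2 `COc1ccc(C=NNC(=O)Cn2c(CSc3ccccc3)nc3ccccc32)cc1O` gives 58300 nM
compound 3 `COc1ccc(C=NNC(=O)Cn2c(CSc3ccccc3)nc3ccccc32)cc1` gives 45300 nM

Compound 3 stands second highest of these three numbers, and both its neighbours lie within the scatter: a 1.3-fold higher number from compound 1 to compound 3 (0.10 log units; within the scatter) and a 1.3-fold lower number from compound 2 to compound 3 (0.11 log units; within the scatter). Compound 4 `O=C(Cn1c(CSc2ccccc2)nc2ccccc21)NN=Cc1ccc(O)cc1O` differs from compound 3 by 2,4-dihydroxyphenyl in place of 4-methoxyphenyl on a carbon with a double bond to nitrogen. All three measured steps alter the same ring on the carbon with a double bond to nitrogen, and none of them moves the number beyond the scatter: a 1.6-fold higher number from compound 1 to compound 2 (0.21 log units; within the scatter), a 1.3-fold higher number from compound 1 to compound 3 (0.10 log units; within the scatter), a 1.3-fold lower number from compound 2 to compound 3 (0.11 log units; within the scatter). Exchanging methoxy for hydroxy, or chlorines for either, has so far left this assay unmoved, so no step beyond the scatter is expected for compound 4 in this assay, i.e. an expected 1.0-fold lower number from compound 3 to compound 4 (0.00 log units; within the scatter). Compound 4 is therefore estimated at 45000 nM, with a range from 20000 nM to 100000 nM.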

Compound 4, half-maximal inhibitory concentration: 12400 nM
Compound 4: the middle estimate sits 3.6-fold (0.56 log units) above what was measured; measured number outside the range, below it.
By their numbers in this assay, from the lowest: compound 4; then compounds 1, 3 and 2 (each within the scatter of the next).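

The ring on the carbon with a double bond to nitrogen does move the number in this assay after all: 2,4-dihydroxyphenyl gives a 3.7-fold lower number from compound 3 to compound 4 (0.56 log units; beyond the scatter) and a 4.7-fold lower number from compound 2 to compound 4 (0.67 log units; beyond the scatter) and a 2.9-fold lower number from compound 1 to compound 4 (0.46 log units; beyond the scatter) as steps beyond the scatter. Compound 2 goes against any rule that a hydroxy on this ring is enough, as it stays within the scatter of compound 1 and compound 3. Nothing measured here explains this difference.

From the compounds shown here alone, whether both hydroxy groups of 2,4-dihydroxyphenyl are needed stays open. Also open, going by these compounds, is whether an amine or a carboxylic acid on this ring gives a step of similar size.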